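From compound 2 to compound 4: an unreadable starting point

The source may hold more compounds than are shown below. What is called first, only, known or untested is meant among the compounds shown, and "the series" means these compounds.

Measured in a functional assay on HL-60 cells (Homo sapiens) for antiproliferative activity, read by MTT assay, with a stated time of 24 h (on this read-out higher numbers stand for weaker inhibition and lower numbers for stronger inhibition), each value being a limit of the assay:
- compound 1 `CCCCc1oc2ccccc2c1C(=O)c1ccc(OCC(N)=O)cc1` gives > 50000 nM
- compound 2 `CCCCc1oc2ccccc2c1C(=O)c1ccc(OCC(=O)N2CCOCC2)cc1` gives > 50000 nM
- compound 3 `CCCCc1oc2ccccc2c1C(=O)c1ccc(OCC(=O)N2CCN(C(=O)OC(C)(C)C)CC2)cc1` gives > 50000 nM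

Compound 2 stands at > 50000 nM in this assay as a limit, not a number. The compound still to be measured is compound 4 `CCCCc1oc2ccccc2c1C(=O)c1ccc(OCCCC(=O)N2CCCC2)cc1`. Its change is 2-((pyrrolidin-1-yl)carbonyl)ethyl in place of (morpholin-4-yl)carbonyl on a saturated chain carbon bound to an oxygen on an aromatic ring, so 2-((pyrrolidin-1-yl)carbonyl)ethyl enters in place of (morpholin-4-yl)carbonyl on a saturated chain carbon bound to an oxygen on an aromatic ring.

Among the measured compounds shown here, the one measured step at this end of the molecule is a step that the two limits leave unreadable from compound 1 to compound 2, and it has no readable size. What the series offers is the limit of > 50000 nM in this assay, at which 3 of the 3 values shown sit, so no change tried so far has produced a number. The step is therefore hard to size, and a reading at the same limit is the likeliest outcome. Any number that did appear would lie on the stronger side of that limit. The expected step is a number no higher from compound 2 to compound 4 (the limit leaves the size open), a rough estimate only. The estimated value for compound 4 is 50000 nM, with an expected range of 15000 nM to 100000 nM.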

Compound 4, half-maximal inhibitory concentration: 29900 nM
The estimate for compound 4 lay 1.7-fold (0.22 log units) above the measured number; low and high end bracket the measured number.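

In this assay compound 4 gives 29900 nM, the first number rather than a limit in this set, and it comes with ((morpholin-4-yl)carbonyl)methyl giving way to 3-((pyrrolidin-1-yl)carbonyl)propyl. Set against the earlier limits, this change reads as an at least 1.6-fold lower number from compound 2 to compound 4 (0.22 log units; that floor lies within the scatter), and the change from the carbamoyl compound reads as an at least 1.6-fold lower number from compound 1 to compound 4 (0.22 log units; that floor lies within the scatter). Both steps are only floors and the step among the earlier compounds cannot be read, so the true size of any gap stays unknown, and the series gives little to size it against: the limit of > 50000 nM in this assay, at which 3 of the 4 values shown sit.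

The change swaps the ring and lengthens the chain at once, so the compounds shown cannot tell which of the two matters. A 3-((morpholin-4-yl)carbonyl)propyl or a ((pyrrolidin-1-yl)carbonyl)methyl group would separate them, and a carboxylic acid at the chain end would show whether an amide is needed there at all.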